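Imidazole substituent: from 2-methylphenyl to isobutyl

The source may hold more compounds than are shown below. What is called first, only, known or untested is meant among the compounds shown, and "the series" means these compounds.

Of the compounds shown here, three sharing one core have been measured in an in vitro functional assay on cells for agonist activity at Bombesin receptor subtype-3 (Mus musculus), read by luminescence and calcium flux; a lower number here means that less compound is needed, a higher number that more compound is needed for the effect. Compound 1 `CCCCc1cnc(C(CCC)Cc2ccc(-c3ccccc3C(=O)O)cc2)[nH]1` gives 165 nM. Compound 2 `Cc1ccccc1Cc1cnc(CCc2ccc(-c3ccccc3C(=O)O)cc2)[nH]1` gives 9.3 nM. Compound 3 `CCC(C)(C)Cc1c[nH]c(CCc2ccc(-c3ccccc3C(=O)O)cc2)n1` gives 9.6 nM. Compound 2 holds the lowest of the three numbers; compound 3 sits within the usual scatter of it, so the two cannot be ordered, while compound 1 lies beyond the scatter, well above both. Compound 1 also differs from the others at more than one place, so no single change can be read off from it.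

The next compound, compound 4 `CC(C)CCc1cnc(CCc2ccc(-c3ccccc3C(=O)O)cc2)[nH]1`, differs from compound 2 only at the imidazole substituent: isobutyl in place of 2-methylphenyl on a saturated chain carbon bound to an aromatic carbon. Among the measured compounds shown here, no pair of measured compounds isolates this change, so the direction of the step is inferred from what compound 3 shows, which carries a branched saturated chain at the same position and gives a number close to compound 2.

Compound 4 is therefore expected to stay in the low range, with a step from compound 2 of a 2.2-fold higher number from compound 2 to compound 4 (0.33 log units; beyond the scatter) expected, at the edge of the scatter, and a value estimated at 20 nM (range 6 nM to 70 nM) because compound 3 gives 9.6 nM with a chain of a similar kind.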

Compound 4, half-maximal effective concentration: 10 nM
Compound 4: middle estimate off by 2.0-fold (0.30 log units), on the high side, and the stated range covers the measured number.
By their numbers in this assay, from the lowest: compounds 2, 3 and 4 (each within the scatter of the next); then compound 1.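

In this assay, placing isobutyl in place of 2-methylphenyl on a saturated chain carbon bound to an aromatic carbon gives a 1.1-fold higher number from compound 2 to compound 4 (0.03 log units; within the scatter), so compound 2 and compound 4 cannot be ordered. Among the compounds shown here, this pair is the first to isolate the position, and it shows directly that, between these two compounds, the six-membered aromatic ring can be exchanged for an open branched chain with no readable difference in the number. The entering group has 4 heavy atoms against 7 in the group that leaves, so in this pair the ring and the additional heavy atoms are not required for a number at this level. No supporting measurement bears on why these two groups read alike.

From the compounds shown here alone, whether this tolerance extends to a group carrying an amine, a hydroxyl or a carboxylic acid at this position, or to a much shorter chain such as ethyl, remains open. Compound 1, at 165 nM, differs from the other compounds at more than one place, so its steps to them cannot be read, and the source of its higher number remains unresolved.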